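This account rests on a few compounds, and the source may have more. Where it says the series, first, only, none or still open, it means among the compounds named here.

Two members of the series are in hand. Compound 1 `CC1(c2ccccc2)CC(=O)N(CC(=O)N2CCN(c3cccc(C(F)(F)F)c3)CC2)C1=O` is recorded in a functional assay on the whole organism (strain CD-1) with Mus musculus as the target, with a stated time of 0.5 h (a lower number here means that less compound is needed, a higher number that more compound is needed for the effect), as "not active" (no number reported), without a number. Compound 2 `CC1(c2ccccc2)CC(=O)N(CC(=O)N2CCN(c3ccc(Cl)cc3)CC2)C1=O` gives in this assay a minimum effective dose of 300 mg/kg. This is the only number shown, so compound 2 stands alone and cannot be placed against another value. Compound 3 `Cc1cccc(N2CCN(C(=O)CN3C(=O)CC(C)(c4ccccc4)C3=O)CC2)c1` is not yet measured. The change from compound 2 to compound 3 is 3-methylphenyl in place of 4-chlorophenyl on an amine nitrogen in a ring. Going by the values given here, no measured step of this kind exists, so the direction is open. In this assay the step is expected to be small, no change at the digits printed from compound 2 to compound 3 (within the scatter), with no change beyond the scatter. For compound 3 the estimate in this assay is 300 mg/kg, within 100 mg/kg to 1000 mg/kg.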

Compound 3, minimum effective dose: "not active" (no number reported)
For compound 3 the study gives words and no number; there is nothing to compare the estimate with.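

Going by these compounds alone, compound 3, like compound 1, is recorded without a number, so no step from compound 2 can be read. The compounds shown leave open how the group on the ring nitrogen relates to the minimum effective dose. No evidence bears on this result.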